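Catechol vinyl sulfone series: variation at the sulfonyl substituent

This account rests on a few compounds, and the source may have more. Where it says the series, first, only, none or still open, it means among the compounds named here.

Measured so far, in a functional assay, read by fluorescence and spectrophotometry, with a stated time of 1 h; a lower number here means that less compound is needed, a higher number that more compound is needed for the effect:
compound 1, `O=S(=O)(/C=C/c1ccc(O)c(O)c1)CC1CCCN1`, gives 13800 nM
compound 2, `CCCCCCS(=O)(=O)/C=C/c1ccc(O)c(O)c1`, gives 7300 nM
compound 3, `O=S(=O)(/C=C/c1ccc(O)c(O)c1)CCCCCCCO`, gives 5900 nM

Compound 1 stands highest of the three numbers in this assay. Its nearest neighbour is compound 2, and the step is a 1.9-fold lower number from compound 1 to compound 2 (0.28 log units; within the scatter). Its furthest is compound 3, with a 2.3-fold lower number from compound 1 to compound 3 (0.37 log units; beyond the scatter). Between the two open-chain analogues the step is a 1.2-fold lower number from compound 2 to compound 3 (0.09 log units; within the scatter). Both measured steps from compound 1 replace the ring entirely with an open chain and move the number a little downward.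

The next compound, compound 4, `CC(C)(C)OC(=O)N1CCCC1CS(=O)(=O)/C=C/c1ccc(O)c(O)c1`, keeps the ring and changes only its nitrogen: tert-butoxycarbonyl in place of hydrogen on an amine nitrogen in a ring. Among the compounds with values here, no measured pair tests a group placed on the amine nitrogen in a ring, so the two steps from compound 1 bear on it only indirectly: they show that loss of the ring amine costs nothing and gives a slightly lower number. A step of similar small size in this assay, toward a lower number or none beyond the scatter, is therefore expected. For compound 4 the estimate in this assay is 9000 nM, with a range from 4000 nM to 20000 nM, which corresponds to an expected 1.5-fold lower number from compound 1 to compound 4 (0.19 log units; within the scatter).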

Compound 4, half-maximal effective concentration: 7100 nM
Compound 4: the middle estimate sits 1.3-fold (0.10 log units) above what was measured; the measured number falls inside the stated range.
By their numbers in this assay, from the lowest: compounds 3, 4, 2 and 1 (each within the scatter of the next, the first and the last beyond it).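

In this assay, the first direct test on the amine nitrogen in a ring gives a 1.9-fold lower number from compound 1 to compound 4 (0.29 log units; within the scatter), so tert-butoxycarbonyl, with 7 heavy atoms and no hydrogen-bond donors, can stand in place of hydrogen without a step beyond the scatter. The open-chain compounds 2 and 3 removed the ring altogether and could not separate the ring from the hydrogen on its nitrogen; compound 4 keeps the ring and shows that this hydrogen is not needed to hold the number within the scatter of compound 1. No measurement on hand explains this tolerance or says how the added group acts at this position.

From the compounds shown here alone, a single group on this nitrogen cannot define the tolerated range, so it remains unknown whether a methyl, an acetyl or a benzyl group would also stay within the scatter of compound 1. Going by these compounds, it also remains open whether a carboxylic acid carried on a chain at this nitrogen would produce a step beyond the scatter in this assay.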